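Compound 4: 4-bromophenyl for 1H-indol-3-yl

The source may report more compounds than this note shows. Statements on the series, on what has been measured and on what is new or still open speak of the compounds shown alone.

Among the measured compounds shown here, in a functional assay on MGC-803 cells (Homo sapiens) for antiproliferative activity, read by MTT assay, with a stated time of 72 h (on this read-out higher numbers stand for weaker inhibition and lower numbers for stronger inhibition), compound 3 `CCCSc1nc(N/N=C/c2c[nH]c3ccccc23)c2nnn(Cc3ccccc3)c2n1` gives 7410 nM as one of only two numbers in the set. The other comes from compound 1 `CCCSc1nc(N/N=C/c2ccccc2Cl)c2nnn(Cc3ccccc3)c2n1` at 10900 nM and the pair does not separate, with a 1.5-fold lower number from compound 1 to compound 3 (0.17 log units; within the scatter) as the step between them. Compound 2 `CCCSc1nc(N/N=C/c2ccc(Cl)cc2)c2nnn(Cc3ccccc3)c2n1` reads > 64000 nM as a limit of the assay and not a number.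

Compound 4 `CCCSc1nc(N/N=C/c2ccc(Br)cc2)c2nnn(Cc3ccccc3)c2n1` is reached from compound 3 by 4-bromophenyl in place of 1H-indol-3-yl on a carbon with a double bond to nitrogen with 4-bromophenyl in place of 1H-indol-3-yl on a carbon with a double bond to nitrogen. The nearest evidence is an at least 8.6-fold lower number from compound 2 to compound 3 (0.93 log units; beyond the scatter) which is the same kind of swap run in reverse, with 4-chlorophenyl standing where compound 4 carries 4-bromophenyl. Further support comes from an at least 5.8-fold higher number from compound 1 to compound 2 (0.76 log units; beyond the scatter) where the 4-chlorophenyl member again falls on the weak side. For the measured compounds named here, both steps hang on compound 2 alone, and no bromine-bearing member has been measured. A clear rise in the number is therefore expected in this assay and that means weaker inhibition. The expected move is a 4.0-fold higher number from compound 3 to compound 4 (0.61 log units; beyond the scatter) and it may end in a limit rather than a number. For compound 4 the estimated value is 30000 nM with an expected range from 10000 nM to 70000 nM on this reasoning.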

Compound 4, half-maximal inhibitory concentration: 34900 nM
For compound 4 the middle estimate is 1.2-fold (0.07 log units) below the measured one; the range from low to high includes it.
By their numbers in this assay, from the lowest: compounds 3 and 1 (each within the scatter of the next); then compound 4. At a limit, above all of these: compound 2.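

In this assay, 4-bromophenyl on the carbon with a double bond to nitrogen gives a measured value where 4-chlorophenyl gave only a limit, so the loss against 1H-indol-3-yl now has a size: a 4.7-fold higher number from compound 3 to compound 4 (0.67 log units; beyond the scatter). The same group also separates from 2-chlorophenyl, with a 3.2-fold higher number from compound 1 to compound 4 (0.51 log units; beyond the scatter), so the weak side of this small set no longer rests on a single compound. Bromo in place of chloro on an aromatic carbon gives an at least 1.8-fold lower number from compound 2 to compound 4 (0.26 log units; that floor lies within the scatter), which supports no claim of a difference between the two halogens, as the chloro member's reading is a limit and not a number: the limit of > 64000 nM in this assay, at which 1 of the 4 values shown sits.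

The compounds shown leave open whether the gap to 1H-indol-3-yl follows from the halogen itself or from the loss of the fused ring and its hydrogen-bond donor; an unsubstituted phenyl, or a phenyl carrying a methoxy group or an amine, would help to separate these readings. As far as these compounds go, how the same order holds with a longer chain in place of the propylthio chain also stays open.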